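Compound 3 to compound 4: chloro in place of isopropyl

The source may hold more compounds than are shown below. What is called first, only, known or untested is meant among the compounds shown, and "the series" means these compounds.

Three members of the series have numbers in a functional assay on MIA PaCa-2 cells (Homo sapiens) for inhibition, read by MTT assay, with a stated time of 72 h; a lower number here means a stronger inhibitor of growth, a higher number a weaker inhibitor of growth. Compound 1 `CC(C)(C)c1ccc(CNCCCNS(=O)(=O)c2cc(C(F)(F)F)cc(C(F)(F)F)c2)cc1` gives 2300 nM. Compound 2 `COc1cccc(CNCCCNS(=O)(=O)c2cc(C(F)(F)F)cc(C(F)(F)F)c2)c1` gives 3400 nM. Compound 3 `CC(C)c1ccc(S(=O)(=O)NCCCCCCNCc2ccc(Br)cc2)cc1` gives 5730 nM. Within the data shown here, the only measured step between compounds differing in a single place is a 1.5-fold higher number from compound 1 to compound 2 (0.17 log units; within the scatter), 3-methoxyphenyl in place of 4-(tert-butyl)phenyl on a saturated chain carbon bound to an amine nitrogen. Compound 3 has the highest of the three numbers; compound 2 is nearest, a gap within the scatter, and compound 1 is furthest, a gap beyond the scatter.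

Compound 4 `O=S(=O)(NCCCCCCNCc1ccc(Br)cc1)c1ccc(Cl)cc1` differs from compound 3 in one place: chloro in place of isopropyl on an aromatic carbon. The change sits on an aromatic carbon of a six-membered aromatic ring of carbon only, para to a large group; cut one bond further out it reads 4-isopropylphenyl to 4-chlorophenyl. Among the measured compounds shown here, no measured step touches this ring: the step from compound 1 to compound 2 concerns the group on the saturated chain carbon and was itself within the scatter, so it offers no guide to the size or direction of the present change. With nothing to support a shift, the expected step is a 1.0-fold lower number from compound 3 to compound 4 (0.00 log units; within the scatter), none beyond the scatter. Compound 4 is therefore estimated at 5700 nM, with a range from 2500 nM to 13000 nM.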

Compound 4, concentration for 50% growth inhibition: 5900 nM
Beside the measured number, compound 4's estimate is 1.0-fold (0.01 log units) below it; measured number inside the range.
By their numbers in this assay, from the lowest: compounds 1, 2, 3 and 4 (each within the scatter of the next, the first and the last beyond it).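

In this assay, among these compounds, the exchange of 4-isopropylphenyl for 4-chlorophenyl gives a 1.0-fold higher number from compound 3 to compound 4 (0.01 log units; within the scatter), the first single-place step on an aromatic carbon of a six-membered aromatic ring of carbon only, para to a large group. In this one pair, therefore, isopropyl with its 3 heavy atoms and chloro with its 1 heavy atom cannot be told apart at this position, whereas the earlier step concerned only the group on the saturated chain carbon bound to an amine nitrogen. Nothing available here accounts for this result, and a single pair sets no trend for the position.

On these data alone, it remains open whether a carboxylic acid, a primary amine or a nitrile on this aromatic carbon would give a step beyond the scatter in this assay, or whether such a group would also fall within it. As far as these compounds go, it is equally open whether the exchange of isopropyl for chloro would read the same on the core of compound 1, which carries a different chain and a different sulfonyl-bound aromatic group.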